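From pyrimidin-2-yl to oxan-4-yl on compound 3

The source may hold more compounds than are shown below. What is called first, only, known or untested is meant among the compounds shown, and "the series" means these compounds.

In a functional assay on A2780 cells (Homo sapiens) for antiproliferative activity, read by CellTiter-Glo, with a stated time of 72 h (a lower number here means a stronger inhibitor, a higher number a weaker inhibitor), compound 1 (`C[C@H](NC(=O)C1CCOCC1)c1ccc(NC(=O)N2CC(c3cccnc3)C2)cc1`) gives 17 nM and compound 2 (`C[C@H](NC(=O)C1CCOCC1)c1ccc(NC(=O)N2CC(c3ccc(N)nc3)C2)cc1`) gives 46 nM in the same test. Within the data shown here, the one measured step between them is a 2.7-fold higher number from compound 1 to compound 2 (0.43 log units; beyond the scatter) and it is a modest one, with amino in place of hydrogen on an aromatic carbon. Compound 3 (`C[C@H](NC(=O)c1ncccn1)c1ccc(NC(=O)N2CC(c3cncc(N)c3)C2)cc1`) has the highest number of the three at 340 nM in this assay and so is the weakest inhibitor of the set.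

Compound 4 (`C[C@H](NC(=O)C1CCOCC1)c1ccc(NC(=O)N2CC(c3cncc(N)c3)C2)cc1`) departs from compound 3 in one place: oxan-4-yl in place of pyrimidin-2-yl on a carbonyl carbon with oxan-4-yl in place of pyrimidin-2-yl on a carbonyl carbon. Among the measured compounds shown here, no measured step makes this exchange, so its size rests on indirect evidence. Compound 4 keeps an amino group and gains the oxan-4-yl group also found in compound 1 and compound 2. The structure of compound 2 is not identical to that of compound 4, but compound 2 at 46 nM is the closest guide. The amino step above stayed modest, so a large step to a lower number is expected in this assay beyond the scatter. The estimated change is an 8.5-fold lower number from compound 3 to compound 4 (0.93 log units; beyond the scatter) for this pair. For compound 4 the expected value is 40 nM with an estimated range from 15 nM to 110 nM in this test.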

Compound 4, half-maximal inhibitory concentration in the A2780 assay: 500 nM
Beside the measured number, compound 4's estimate is 13-fold (1.10 log units) below it; the whole stated range lies below it.
By their numbers in the A2780 assay, from the lowest: compound 1; then compound 2; then compounds 3 and 4 (each within the scatter of the next).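

In the A2780 assay compound 3 gives 340 nM and compound 4 gives 500 nM and the exchange at this carbonyl carbon gives a 1.5-fold higher number from compound 3 to compound 4 (0.17 log units; within the scatter), so with the 5-aminopyridin-3-yl group in place, the compounds shown do not separate oxan-4-yl from pyrimidin-2-yl at this position. In a physicochemical assay for solubility, read by LC-MS, in phosphate buffer, with a stated time of 24 h, at pH 6.8 (on this read-out higher numbers stand for higher solubility and lower numbers for lower solubility), compound 3 gives 300000 nM and compound 4 gives 440000 nM and the same exchange gives a 1.5-fold higher number from compound 3 to compound 4 (0.17 log units; within the scatter), so that read-out does not separate the two groups either. The large changes lie at the other end of the molecule: back in the A2780 assay, 5-aminopyridin-3-yl in place of 6-aminopyridin-3-yl gives an 11-fold higher number from compound 2 to compound 4 (1.04 log units; beyond the scatter), and amino in place of hydrogen at this ring position gives a 29-fold higher number from compound 1 to compound 4 (1.47 log units; beyond the scatter), far more than the modest 2.7-fold higher number from compound 1 to compound 2 (0.43 log units; beyond the scatter) seen when the amino group occupies the position found in compound 2.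

The data shown offer no measured reason why the position of the amino group matters so much or why the two groups at the carbonyl carbon read alike. Going by these compounds, whether those groups also read alike alongside the 6-aminopyridin-3-yl group remains open, as does how a piperidin-4-yl group would behave on the same carbonyl carbon.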